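This account rests on a few compounds, and the source may have more. Where it says the series, first, only, none or still open, it means among the compounds named here.

For the measured compounds named here, in an ADME assay on the whole organism for inhibition, with Echinochloa crus-galli var. formosensis as the target, with a stated time of 4 days (on this read-out lower numbers stand for stronger inhibition and higher numbers for weaker inhibition), compound 1 `CCN(c1nc(Cl)nc(N[C@H](C)c2ccccc2)n1)C(C)C` gives 52500 nM, the highest of the three numbers so far, which makes it the weakest inhibitor of the set. Compound 2 `CCCNc1nc(Cl)nc(N[C@@H](C)c2ccccc2)n1` reads 15100 nM, and compound 3 `CCCN(CC)c1nc(Cl)nc(N[C@@H](C)c2ccccc2)n1` reads 282 nM. The next compound, compound 4 `CC[C@H](C)Nc1nc(Cl)nc(N[C@H](C)c2ccccc2)n1`, changes one group on the core of compound 1: (sec-butyl)amino in place of ethyl(isopropyl)amino on an aromatic carbon. Here (sec-butyl)amino stands in place of ethyl(isopropyl)amino on an aromatic carbon, so the nitrogen of this group keeps a hydrogen, as it does in compound 2. Going by the values given here, the one measured step that bears on this is large: a 54-fold lower number from compound 2 to compound 3 (1.73 log units; beyond the scatter), with ethyl in place of hydrogen on a nitrogen on an aromatic ring. Read in reverse, it points towards a higher number for compound 4. The comparison is loose, however. Among the compounds with values here, compound 2 and compound 3 have the opposite handedness at the stereocentre of the other side chain, the one that compound 1 and compound 4 share. The data also do not show how much higher the numbers can go. The expected change is therefore modest, a 1.7-fold higher number from compound 1 to compound 4 (0.23 log units; within the scatter), and not clearly beyond the scatter. For compound 4 the estimated value is 90000 nM, with an expected range from 25000 nM to 300000 nM.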

Compound 4, half-maximal inhibitory concentration: 52500 nM
The estimate for compound 4 lay 1.7-fold (0.23 log units) above the measured number; the measured number falls inside the stated range.
By their numbers in this assay, from the lowest: compound 3; then compound 2; then compounds 1 and 4 (each within the scatter of the next).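

In this assay the aromatic carbon opposite the ring nitrogen accepts (sec-butyl)amino in place of ethyl(isopropyl)amino with no change at the digits printed from compound 1 to compound 4 (within the scatter), even though the entering group has a hydrogen-bond donor and the leaving group has none. On the core of compound 1, then, a hydrogen on this nitrogen does not by itself shift the number, and the large 54-fold lower number from compound 2 to compound 3 (1.73 log units; beyond the scatter) does not carry over to this pair, although the two pairs have opposite handedness at the stereocentre of the other side chain and so compare only loosely. No measured evidence here bears on why the two numbers agree.

From the compounds shown here alone, it remains open whether the amino group of compound 3, which reads 282 nM, would bring a similarly low number when paired with the side-chain handedness of compound 1. Also unsettled is whether the opposite handedness in the sec-butyl group, or a longer chain such as hexylamino, would move the number on this core.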